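Alkyl variation on the amide nitrogen, paw edema read-out

The compounds below may be only part of what the source reports. "The series", "measured", "known", "first", "only" and "open" are said of these compounds alone.

Compound 1 `CCCCNC(=O)CC1CCc2cc(OC)c(OC)cc21` and compound 2 `COc1cc2c(cc1OC)C(CC(=O)NC(C)(C)C)CC2` share one core and differ only in the group on the amide-type nitrogen. In a functional assay on the whole organism (strain Wistar) for inhibition, with Rattus norvegicus as the target, read by paw edema, with stated times of 60 min and 1 h, at a dose of 100 mg/kg by the oral route (on this read-out higher numbers stand for more inhibition at the one dose given (going by the name of the read-out) and lower numbers for less inhibition), compound 1 gives 31.3% and compound 2 gives 31.3%, so compound 2 stands level with compound 1; the step of no change at the digits printed from compound 1 to compound 2 (within the scatter). Compound 3 `CCCCCNC(=O)CC1CCc2cc(OC)c(OC)cc21` carries pentyl in place of tert-butyl on an amide-type nitrogen. For the measured compounds named here, only the step from compound 1 to compound 2 bears on this change, and it lay within the scatter, so no step beyond the scatter is expected in this assay in either direction. Compound 3 is estimated at 31%, with a range of 18% to 44%, the expected step being a number 0.3 percentage points lower from compound 2 to compound 3 (within the scatter).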

Compound 3, a percentage reported as inhibition, in the whole organism at one dose (the size of the read-out at that dose, not a potency): 34.4%
The estimate for compound 3 lay 3.4 percentage points below the measured number; the measured number falls inside the stated range.
By their numbers in this assay, from the lowest: compounds 1, 2 and 3 (each within the scatter of the next).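

In this assay the pentyl group on the amide-type nitrogen reads level with tert-butyl, with a number 3.1 percentage points higher from compound 2 to compound 3 (within the scatter) and, against butyl, with a number 3.1 percentage points higher from compound 1 to compound 3 (within the scatter). Across these three alkyl groups, neither the branched tert-butyl nor the longer pentyl chain separates from butyl beyond the scatter at the one dose given. Nothing available explains why the three read alike. Still open, on these data alone, is how a cyclohexyl or benzyl group, or a chain ending in an amine or a carboxylic acid, on this nitrogen would read.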